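This account rests on a few compounds, and the source may have more. Where it says the series, first, only, none or still open, it means among the compounds named here.

Measured compounds in a functional assay on BXPC-3 cells (Homo sapiens) for cytotoxicity, read by MTT assay, with a stated time of 72 h; a higher number here means a weaker inhibitor, a lower number a stronger inhibitor:
Compound 1 `O=C1C(NCc2ccc(F)cc2)=CC(=O)c2ncncc21` gives 1400 nM.
Compound 2 `COc1ccc(-c2ccc(NC3=CC(=O)c4ncncc4C3=O)cc2)cc1` gives 3500 nM.
Compound 3 `O=C1C(Nc2cccc(B(O)O)c2)=CC(=O)c2ncncc21` is recorded only as a limit, > 10000 nM.

Three compounds share one core and differ in what hangs on the amine. Of the two numbers that were actually obtained in this assay, compound 2 carries the higher one; compound 1 sits at the lower number, and the gap between them lies beyond the usual scatter of repeated measurements. Compound 3 reaches only (the limit of > 10000 nM in this assay, at which 1 of the 3 values shown sits), so no number can be put beside it.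

The compound that follows is compound 4 `CCOC(=O)c1ccc(NC2=CC(=O)c3ncncc3C2=O)cc1`. It comes from compound 2 by ethoxycarbonyl in place of 4-methoxyphenyl on an aromatic carbon. Going by the values given here, no pair among the measured compounds differs in just this one place, so nothing of the same kind has been measured to set the size of the step. Among the compounds with values here, what remains is the single neighbour that ended at the limit and the two compounds with numbers, which leave room on either side. Compound 4 is therefore expected to stay close to compound 2, with a step of a 1.1-fold higher number from compound 2 to compound 4 (0.06 log units; within the scatter) that is expected to be small and not clearly beyond the scatter. For compound 4 the estimate is 4000 nM, within a range from 1500 nM to 12000 nM.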

Compound 4, half-maximal inhibitory concentration: 5900 nM
The estimate for compound 4 lay 1.5-fold (0.17 log units) below the measured number; measured number inside the range.
By their numbers in this assay, from the lowest: compound 1; then compounds 2 and 4 (each within the scatter of the next). At a limit, above all of these: compound 3.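

In this assay, putting ethoxycarbonyl in place of 4-methoxyphenyl on this aromatic carbon gives a 1.7-fold higher number from compound 2 to compound 4 (0.23 log units; within the scatter), the first step measured between two compounds that differ in one place. The number stays within the scatter even though the entering group has no ring and 5 heavy atoms, while the leaving group has a six-membered aromatic ring of carbon only and 8 heavy atoms, so the outer aromatic ring of compound 2 is not needed to hold the number at this level in this assay. Nothing measured among these compounds explains why the two groups give such similar numbers.

The compounds shown leave open whether a carboxylic acid or a primary amide on the same carbon would also stay within the scatter of compound 2, and whether a longer ester chain than the ethyl of compound 4 would do the same. They also leave open what a small group such as a methoxy group or a chlorine atom would give at this place, with neither a ring nor a carbonyl present.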